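Sulfonamide series: methyl in place of the aryl group

The source may report more compounds than this note shows. Statements on the series, on what has been measured and on what is new or still open speak of the compounds shown alone.

Compound 1 `Cc1ccccc1S(=O)(=O)Nc1ccc2oc(-c3ccccc3)nc2c1`, compound 2 `O=S(=O)(Nc1ccc2oc(-c3ccccc3)nc2c1)c1ccccc1Cl` and compound 3 `C=Cc1ccc(S(=O)(=O)Nc2ccc3oc(-c4ccccc4)nc3c2)cc1` share one core and differ only in the group on the sulfonyl sulfur. In an ADME assay on HEK293 cells (Homo sapiens) for cytotoxicity, read by resazurin assay, with a stated time of 48 h (on this read-out higher numbers stand for lower toxicity in this test and lower numbers for higher toxicity in this test), compound 1 gives 57000 nM, compound 2 gives 73000 nM and compound 3 gives 53000 nM. The three numbers sit close together: a 1.3-fold higher number from compound 1 to compound 2 (0.11 log units; within the scatter), a 1.1-fold lower number from compound 1 to compound 3 (0.03 log units; within the scatter) and a 1.4-fold lower number from compound 2 to compound 3 (0.14 log units; within the scatter), so compound 3 cannot be set apart from the other two on this read-out. Compound 4 `CS(=O)(=O)Nc1ccc2oc(-c3ccccc3)nc2c1` is the next member, and the change from compound 3 is methyl in place of 4-vinylphenyl on a sulfonyl sulfur. Among the measured compounds shown here, none of the measured steps bears directly on this change: each of them exchanges one substituted phenyl for another on the sulfonyl sulfur or alters a substituent on such a ring, and all three stayed within the scatter. For the measured compounds named here, no measured pair tests the loss of the ring itself. Given that the measured compounds show no movement in this assay across their differences, the expected step from compound 3 to compound 4 is a 1.3-fold higher number from compound 3 to compound 4 (0.12 log units; within the scatter), that is, nothing beyond the scatter. Compound 4 is therefore estimated at 70000 nM in this assay, with a range from 35000 nM to 150000 nM.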

Compound 4, half-maximal cytotoxic concentration: > 100000 nM
Compound 4: no number, only a limit; the forecaster's own chance of this, stated with the estimate: 20%; middle value at least 1.4-fold (0.15 log units) away from the limit.
By their numbers in this assay, from the lowest: compounds 3, 1 and 2 (each within the scatter of the next). At a limit, above all of these: compound 4.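

In this assay, the reading for compound 4, with methyl on the sulfonyl sulfur, is a limit and not a number: the limit of > 100000 nM in this assay, at which 1 of the 4 values shown sits. Among the compounds shown here, this is the first view of the loss of the ring itself, and the steps read as floors: an at least 1.8-fold higher number from compound 3 to compound 4 (0.27 log units; that floor lies within the scatter), an at least 1.7-fold higher number from compound 1 to compound 4 (0.24 log units; that floor lies within the scatter) and an at least 1.3-fold higher number from compound 2 to compound 4 (0.13 log units; that floor lies within the scatter). Each floor lies within the scatter, so the loss of the ring cannot be placed beyond it, yet methyl on this sulfonyl sulfur gives no lower number than any of the three aryl groups.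

From the compounds shown here alone, the true size of all three steps remains open as long as compound 4 stands at a limit. Also open, going by these compounds, is how this read-out responds to an ethyl group, a longer chain or a chain ending in an amine or a carboxylic acid on the sulfonyl sulfur.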